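This account rests on a few compounds, and the source may have more. Where it says the series, first, only, none or still open, it means among the compounds named here.

Measured compounds in a functional assay on BCG823 cells (Homo sapiens) for inhibition, read by MTT assay, with a stated time of 72 h; a lower number here means a stronger inhibitor, a higher number a weaker inhibitor:

compound 1 `CN(C(=O)NC(=O)c1ccc(F)c(F)c1)c1nc(C(F)(F)F)c(C(=O)N/N=C/c2ccc([N+](=O)[O-])cc2)s1` — 2.99 ug/mL
compound 2 `CN(C(=O)NC(=O)c1c(F)cccc1F)c1nc(C(F)(F)F)c(C(=O)N/N=C/c2cc(C(F)(F)F)cc(C(F)(F)F)c2)s1` — 5.28 ug/mL
compound 3 `Cc1nc(N(C)C(=O)NC(=O)c2ccc(Cl)cc2Cl)sc1C(=O)N/N=C/c1ccc(C(F)(F)F)cc1` — 38 ug/mL

Compound 2 sits between the other two numbers. Its gap to compound 1 is within the usual scatter, so the two cannot be told apart by this assay; its gap to compound 3 is beyond the scatter, compound 3 having the weaker number of the pair. Compound 3 also carries a different core, so nothing about a single change can be read from it.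

Compound 4 `CN(C(=O)NC(=O)c1c(F)cccc1F)c1nc(C(F)(F)F)c(C(=O)N/N=C/c2cccc(C(F)(F)F)c2)s1` is not yet measured. It differs from compound 2 in one place: hydrogen in place of trifluoromethyl on an aromatic carbon. The partner ring keeps its remaining trifluoromethyl group.

Going by the values given here, no step between two measured compounds isolates such a change, so there is no anchor for its size. Loss of a trifluoromethyl group is a modest change, and the expectation is a step from compound 2 to compound 4 of a 1.2-fold higher number from compound 2 to compound 4 (0.09 log units; within the scatter), on the weaker side but not clearly beyond the scatter. Compound 4 is therefore expected to give about 6.5 ug/mL in this assay, with a plausible range from 2.5 ug/mL to 18 ug/mL.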

Compound 4, half-maximal inhibitory concentration: 25.9 ug/mL
Compound 4: the middle estimate sits 4.0-fold (0.60 log units) below what was measured, outside the stated range (above it).
By their numbers in this assay, from the lowest: compounds 1 and 2 (each within the scatter of the next); then compounds 4 and 3 (each within the scatter of the next).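

Going by these compounds alone, replacing trifluoromethyl with hydrogen on this aromatic carbon gives, in this assay, a 4.9-fold higher number from compound 2 to compound 4 (0.69 log units; beyond the scatter), and this is the first single-place step. The position is therefore not silent. The other trifluoromethyl group and the rest of the molecule stay unchanged, and this one substitution moves the number in the weaker direction, beyond the usual scatter of repeat measurements. No measured property of these compounds bears on the step, and the data give no explanation for it.

Whether the step reflects something particular to trifluoromethyl or the presence of any group at this aromatic carbon remains open, since the compounds shown carry only trifluoromethyl or hydrogen here, and a chlorine atom, a methoxy group or an amine at the same carbon would help separate the two readings. Also open, on these data alone, is whether the same replacement would give a step of similar size when the rest of the molecule differs, as a single step cannot show how far this result carries across the series.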